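The compounds below may be only part of what the source reports. "The series", "measured", "known", "first", "only" and "open" are said of these compounds alone.

Compound 1 `Cc1ccccc1-n1nncc1CN1C(=O)C2(C(C#N)=C(N)Oc3c2c2nc4ccccc4nc2c2ccccc32)c2ccccc21`: > 50000 nM
Compound 2 `N#CC1=C(N)Oc2c(N)cc3nc4ccccc4nc3c2C12C(=O)N(Cc1cnnn1-c1cccc(Br)c1)c1ccccc12`: 18900 nM

Both were tested in a functional assay on A549 cells (Homo sapiens) for antiproliferative activity, read by MTT assay, with a stated time of 48 h; on this read-out higher numbers stand for weaker inhibition and lower numbers for stronger inhibition. For compound 1 the result is a limit of the assay, > 50000 nM. Compound 2 gives an actual number, 18900 nM, and is the only compound among those shown to do so. The other value shown is the limit of > 50000 nM in this assay, at which 1 of the 2 values shown sits, and it belongs to compound 1. Compound 1 and compound 2 differ in more than one place, so their two values show only that one stays at the limit while the other gives a number; no single step can be read from them.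

Compound 3 `CCOc1ccccc1-n1nncc1CN1C(=O)C2(C(C#N)=C(N)Oc3c(N)cc4nc5ccccc5nc4c32)c2ccccc21` has not yet been measured in this assay. It differs from compound 2 in one place: 2-ethoxyphenyl in place of 3-bromophenyl on an aromatic nitrogen. Going by the values given here, no step between two measured compounds that differ in only one place is available, so nothing shows how a change of this kind moves the result in this assay. The expected step from compound 2 to compound 3 is a 1.2-fold higher number from compound 2 to compound 3 (0.07 log units; within the scatter), not beyond the usual scatter. Compound 3 is estimated at 22000 nM, with a range from 8000 nM to 60000 nM.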

Compound 3, half-maximal inhibitory concentration: > 50000 nM
Compound 3: only a limit was reported; the forecaster's own chance of this, stated with the estimate: 30%; at least 2.2-fold (0.35 log units) between middle value and limit.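

Going by these compounds alone, replacing 3-bromophenyl with 2-ethoxyphenyl on the aromatic nitrogen of the five-membered ring gives the first change in one place that can be read in this assay, and it produces an at least 2.6-fold higher number from compound 2 to compound 3 (0.42 log units; beyond the scatter). This shows that the result is not indifferent to the aromatic group at this position, something the earlier pair could not show, since those two compounds differ in more than one place. Compound 3 gives > 50000 nM, which is a limit and not a number, so the step is a minimum and its full size stays unknown, and compound 3 now joins the compounds at that limit: the limit of > 50000 nM in this assay, at which 2 of the 3 values shown sit.

With only this one swap, the compounds shown cannot separate the effect of losing the bromine from that of gaining the ethoxy group, and they do not show how much of the change comes from where each group sits on the ring. A plain phenyl group, or a phenyl ring carrying an amine or a carboxylic acid, would be needed to show how widely the result moves at this position.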